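The source may report more compounds than this note shows. Statements on the series, on what has been measured and on what is new or still open speak of the compounds shown alone.

Measured so far:
- compound 1, `COc1cc(-c2nnc(Sc3ncnc4c(OC)c(OC)c(OC)cc34)s2)cc(OC)c1OC`: 8700 nM
- compound 2, `C=CCSc1ncnc2ccccc12`: 48000 nM

In a functional assay on PC-3 cells (Homo sapiens) for antiproliferative activity, read by MTT assay (a lower number here means a stronger inhibitor, a higher number a weaker inhibitor), compound 2 gives the highest of the two numbers; compound 1 gives a lower number, and that gap lies beyond the scatter. Nothing else ties the two together, as they share no single-point change.

Compound 3, `C=CCSc1ncnc2ccc(I)cc12`, is not yet measured. It differs from compound 2 in one place, (iodo in place of hydrogen on an aromatic carbon), on the carbon-only ring of the fused two-ring system. Going by the values given here, no measured pair shows what such a change does here, so the size of the step in this assay rests on expectation alone: a small one, if any, most likely toward a lower number, and quite possibly none beyond the scatter.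

The step from compound 2 to compound 3 is therefore estimated at a 1.6-fold lower number from compound 2 to compound 3 (0.20 log units; within the scatter). Compound 3 is expected to give about 30000 nM in this assay, within a range of 10000 nM to 100000 nM.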

Compound 3, half-maximal inhibitory concentration: 28800 nM
Compound 3: middle estimate off by 1.0-fold (0.02 log units), on the high side; the range from low to high includes it.
By their numbers in this assay, from the lowest: compound 1; then compounds 3 and 2 (each within the scatter of the next).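

In this assay, going by these compounds alone, iodo in place of hydrogen on an aromatic carbon gives a 1.7-fold lower number from compound 2 to compound 3 (0.22 log units; within the scatter), the first single-place change that can be read. At this position on the carbon-only ring, meta to a fused ring and para to a fused ring, adding one iodine atom, with no hydrogen-bond donors or acceptors, therefore does not separate compound 3 from compound 2. No measured evidence bears on why the step has this size.

From the compounds shown here alone, whether an amine or a carboxylic acid on this same carbon would move the number beyond the scatter remains open. Also open, going by these compounds, is whether iodo would give a similar step on the core of compound 1, or with a longer chain on the sulfur of compound 3.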